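This account rests on a few compounds, and the source may have more. Where it says the series, first, only, none or still open, it means among the compounds named here.

Compound 1, `COc1ccc(-c2cnc(NC(=O)c3cccnc3)n2C)cc1`: > 100000 nM
Compound 2, `COc1ccc(-c2cnc(NC(=O)c3ccccc3)n2C)cc1`: > 100000 nM

Both values come from a toxicity assay on THP-1 cells (Homo sapiens) for inhibition; a lower number here means that less compound is tolerated, a higher number that more compound is tolerated. For compound 2 the value is only a limit of the assay, not a measured number. The same holds for compound 1. Within the data shown here, the one step within the measured pair, a step that the two limits leave unreadable from compound 1 to compound 2, therefore cannot be sized, since (the limit of > 100000 nM in this assay, at which 2 of the 2 values shown sit). Compound 3, `COc1ccc(-c2cnc(NC(=O)c3ccn[nH]3)n2C)cc1`, has not been measured yet. It differs from compound 2 in one place: 1H-pyrazol-5-yl in place of phenyl on a carbonyl carbon. Among the measured compounds shown here, the only measured step bears on this change merely as the other exchange at the same carbonyl carbon, and it gave no readable size. Nothing in the numbers points to a change beyond the usual scatter, so the step from compound 2 to compound 3 is expected to be a number no higher from compound 2 to compound 3 (the limit leaves the size open) in this assay. Compound 3 is therefore estimated at 100000 nM, between 40000 nM and 300000 nM, most likely reported again as a limit.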

Compound 3, half-maximal cytotoxic concentration: > 100000 nM
Compound 3 ended at the assay's limit (the forecaster's own chance of this, stated with the estimate: 85%); the middle value sits exactly at the limit.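

Compound 3 gives > 100000 nM in this assay, which is a limit of the assay and not a number. No step among compound 1, compound 2 and compound 3 can therefore be read: the limit of > 100000 nM in this assay, at which 3 of the 3 values shown sit.

The compounds shown leave open whether any exchange on the carbonyl carbon changes the concentration that THP-1 cells tolerate.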